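A few compounds are considered here, and "the series" means these few. Any claim that something is new, unique, unknown or untested is made for them only; others in the source may bear on it.

Working notes on the series. Compound 1 `CCOC(=O)/C=N/c1cnc(Nc2ccc(S(N)(=O)=O)cc2)nc1NC1CCCC1` and compound 2 `NS(=O)(=O)c1ccc(Nc2ncc(/N=C/c3ccc(C(F)(F)F)cc3)c(NC3CCCC3)n2)cc1` share one core; in a functional assay on MCF7 cells (Homo sapiens) for antiproliferative activity, read by MTT assay (on this read-out lower numbers stand for stronger inhibition and higher numbers for weaker inhibition), compound 1 gives 42200 nM. For compound 2 the result in this assay is only a limit of the assay, > 100000 nM. Among the measured compounds shown here, the one measured step, an at least 2.3-fold higher number from compound 1 to compound 2 (0.37 log units; beyond the scatter), therefore rests on the limit of > 100000 nM in this assay, at which 1 of the 2 values shown sits, and marks a drop in potency. Compound 3 `CC(C)Nc1nc(Nc2ccc(S(N)(=O)=O)cc2)ncc1/N=C/c1ccc(C(F)(F)F)cc1` differs from compound 2 by isopropyl in place of cyclopentyl on a nitrogen on an aromatic ring. For the measured compounds named here, no measured step touches the group on the nitrogen on the aromatic ring; the single measured step concerns the carbon with a double bond to nitrogen and offers no direction for this exchange. With compound 2 at the limit, the numbers shown cannot fix a step in this assay for this change. Compound 3 is expected to stay near the limit, estimated at 100000 nM within a range of 30000 nM to 300000 nM. The implied step, a number no higher from compound 2 to compound 3 (the limit leaves the size open), is expected to be none beyond the scatter.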

Compound 3, half-maximal inhibitory concentration: > 100000 nM
Compound 3: only a limit was reported; the forecaster's own chance of this, stated with the estimate: 65%; the middle value sits exactly at the limit.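

No step can be read from compound 2 to compound 3 in this assay, as both compounds stand at a limit of the assay: the limit of > 100000 nM in this assay, at which 2 of the 3 values shown sit.

The compounds shown leave open what isopropyl in place of cyclopentyl on a nitrogen on an aromatic ring does in this assay.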